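The compounds below may be only part of what the source reports. "The series", "measured", "known", "first", "only" and "open" are said of these compounds alone.

Measured compounds:
Compound 1 `Cc1ccc(C(=O)CCc2nnc(-c3ccccc3)o2)cc1` gives 33.3% in a functional assay on the whole organism (strain Wistar) for inhibition, with Rattus norvegicus as the target, with stated times of 30 min and 2 h, at a dose of 20 mg/kg by the oral route; on this read-out higher numbers stand for more inhibition at the one dose given (going by the name of the read-out) and lower numbers for less inhibition.
Compound 2 `Cc1ccc(C(=O)CCc2nnc(-c3ccccc3Cl)o2)cc1` gives 36.2% in this assay.
Compound 3 `Cc1ccc(C(=O)CCc2nnc(-c3ccccc3)o2)c(C)c1` gives 36% in this assay.

All three numbers sit close together. The step of a number 2.9 percentage points higher from compound 1 to compound 2 (within the scatter) corresponds to the change (chloro in place of hydrogen on an aromatic carbon). The step of a number 2.7 percentage points higher from compound 1 to compound 3 (within the scatter) corresponds to the change (methyl in place of hydrogen on an aromatic carbon), which is also how the cores of compound 1 and compound 3 differ. Compound 2 and compound 3 differ from each other by two changes, and their two values show no gap that stands out of the scatter.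

Compound 4 `Cc1ccc(C(=O)CCc2nnc(-c3ccccc3Cl)o2)c(C)c1` has not been measured in this assay. It differs from compound 3 by chloro in place of hydrogen on an aromatic carbon. This is the same change as that made from compound 1 to compound 2, occurring twice among the compounds shown, both times at a place described in the same words, so the two are the same change rather than merely the same kind. Going by the values given here, the only measured instance of it lies within the scatter, and the change of core from compound 1 to compound 3 also left the number within the scatter. Among the compounds with values here, nothing among the three measured compounds suggests that the two changes combine to anything larger than their single steps.

For compound 4 the expected step is a number 3 percentage points higher from compound 3 to compound 4 (within the scatter), resting on the size of the step from compound 1 to compound 2 a number 2.9 percentage points higher from compound 1 to compound 2 (within the scatter) applied to compound 3. Compound 4 is therefore estimated at 39%, with a likely range from 29% to 49%.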

Compound 4, a percentage reported as inhibition, in the whole organism at one dose (the size of the read-out at that dose, not a potency): 33.5%
Beside the measured number, compound 4's estimate is 5.5 percentage points above it, and the stated range covers the measured number.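

In this assay, phenyl to 2-chlorophenyl on the core of compound 3 gives a number 2.5 percentage points lower from compound 3 to compound 4 (within the scatter), and beside the same change on the core of compound 1 it shows no difference that stands out of the scatter: the same change on two cores in this assay, a number 2.9 percentage points higher (within the scatter) from compound 1 to compound 2 and a number 2.5 percentage points lower (within the scatter) from compound 3 to compound 4, 5.4 percentage points apart, within the scatter of two such steps. The methyl change, now read with the chloro group in place, gives a number 2.7 percentage points lower from compound 2 to compound 4 (within the scatter), and it too matches its earlier instance within the scatter: the same change on two cores in this assay, a number 2.7 percentage points higher (within the scatter) from compound 1 to compound 3 and a number 2.7 percentage points lower (within the scatter) from compound 2 to compound 4, 5.4 percentage points apart, within the scatter of two such steps. Both changes therefore carry from one core to the other in these four compounds without any step leaving the scatter, but the steps are too small to show that either change raises or lowers inhibition, and their signs cannot be read as a reversal or as an interaction of the two groups.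

The compounds shown leave open whether any substituent on these aromatic rings moves the read-out out of the scatter, for example an amine or a carboxylic acid in place of the chloro group, or whether a longer chain in place of the one carrying the carbonyl does so. They also leave open whether the four compounds would separate at other doses, since the read-out gives the size of the inhibition at one dose and not a potency.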